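This account rests on a few compounds, and the source may have more. Where it says the series, first, only, none or still open, it means among the compounds named here.

The measured compounds are:
compound 1, `COc1cccc(C(O)CCn2nc3c(Br)c(Br)c(Br)c(Br)c3n2)c1`, which in a functional assay on MCF7 cells (Homo sapiens) for antiproliferative activity, read by MTT assay, with a stated time of 24 h, tested at 100 uM (a lower number here means a stronger effect, a higher number a weaker effect of the compound at the concentration tested), gives 16%;
compound 2, `C[C@@H](O)CCn1nc2c(Br)c(Br)c(Br)c(Br)c2n1`, which in this assay gives 18%;
compound 3, `C[C@H](O)CCn1nc2c(Br)c(Br)c(Br)c(Br)c2n1`, which in this assay gives 31%.

Compound 1 stands lowest of the three numbers. Its nearest neighbour is compound 2, whose value lies within the scatter of it, and the furthest is compound 3, whose value lies beyond the scatter above it. Among the measured compounds shown here, the one step that can be followed within the set is a number 13 percentage points higher from compound 2 to compound 3 (beyond the scatter), and the fact that compounds 2 and 3 differ only in the configuration as drawn is all that separates these two compounds.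

Compound 4, `OC(CCn1nc2c(Br)c(Br)c(Br)c(Br)c2n1)c1ccc(Br)cc1`, is not yet measured in this assay. It differs from compound 1 in one place: 4-bromophenyl in place of 3-methoxyphenyl on a saturated chain carbon bound to an oxygen on a saturated carbon and a saturated chain carbon. For the measured compounds named here, no measured step changes the aryl group on that chain carbon; the only step in hand, between compound 2 and compound 3, concerns configuration alone and offers no guide to an exchange of one aryl group for another. Compound 4 is therefore expected to stay close to compound 1, with a step of a number 4 percentage points higher from compound 1 to compound 4 (within the scatter) that is not expected to go beyond the scatter. The estimate for compound 4 in this assay is 20%, between 8% and 40%.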

Compound 4, a percentage reported as activity, at one concentration (the size of the read-out at that concentration, not a potency): 0%
The estimate for compound 4 lay 20 percentage points above the measured number; measured number below the stated range.
By their numbers in this assay, from the lowest: compound 4; then compounds 1 and 2 (each within the scatter of the next); then compound 3.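

In this assay, placing 4-bromophenyl in place of 3-methoxyphenyl on the saturated chain carbon that carries the hydroxyl oxygen gives a number 16 percentage points lower from compound 1 to compound 4 (beyond the scatter). The earlier compounds shown here showed only that configuration at a saturated chain carbon can change this read-out; this pair shows that the aryl group at this position matters as well, and that a single exchange there can produce a step beyond the scatter, in the direction of a stronger effect at the concentration tested. Among the compounds shown here, nothing measured here on the two aryl groups accounts for the step, and the one available comparison of configuration has no bearing on it.

The exchange alters both the substituent and its place on the ring at once, so the compounds shown leave open whether the step follows from gaining bromine, losing methoxy, or the change of place, which 3-bromophenyl, 4-methoxyphenyl or unsubstituted phenyl would help to separate. They also leave open how far the pattern extends to other groups at this carbon, such as a pyridyl ring or a simple ethyl chain, and whether the configuration of this carbon, not drawn in compound 1 or compound 4, matters.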